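Swapping the carbonyl substituent of compound 2

A few compounds are considered here, and "the series" means these few. Any claim that something is new, unique, unknown or untested is made for them only; others in the source may bear on it.

In a functional assay on NCI-H1581 cells (Homo sapiens) for antiproliferative activity, read by CCK-8 assay, with a stated time of 72 h (on this read-out higher numbers stand for weaker inhibition and lower numbers for stronger inhibition), compound 1 (`COc1cc(OC)c(Cl)c(-c2ccc3c(NC(=O)c4ccc(N5CCCN(C)CC5)cc4)n[nH]c3n2)c1Cl`) gives 1.3 nM and compound 2 (`COc1cc(OC)c(Cl)c(-c2ccc3c(NC(=O)c4ccc(N5CCN(C)CC5)s4)n[nH]c3n2)c1Cl`) gives 3.7 nM as the higher of the two numbers, a gap beyond the usual scatter. Compound 3 (`COc1cc(OC)c(Cl)c(-c2ccc3c(NC(=O)c4ccc(N(C)C)cc4)n[nH]c3n2)c1Cl`) has no number yet in this assay and differs from compound 2 by one change (a group of 9 heavy atoms (8 carbon, 1 nitrogen; one six-membered aromatic ring of carbon only) in place of a group of 12 heavy atoms (9 carbon, 2 nitrogen, 1 sulfur; one five-membered aromatic ring with 1 hetero atom, one six-membered non-aromatic ring with 2 hetero atoms), on a carbonyl carbon) that puts 4-(dimethylamino)phenyl on the carbonyl carbon. For the measured compounds named here, no measured compound carries this group. The expectation therefore rests on two anchors only, compound 1 at 1.3 nM and compound 2 at 3.7 nM as the closer reference. A moderate move toward weaker inhibition is expected, an estimated 2.2-fold higher number from compound 2 to compound 3 (0.33 log units; beyond the scatter) with a wide margin on either side. Compound 3 is expected at an estimated 8 nM (2 nM to 30 nM).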

Compound 3, half-maximal inhibitory concentration: 294 nM
Compound 3: the middle estimate sits 37-fold (1.57 log units) below what was measured, and the stated range ends below it.
By their numbers in this assay, from the lowest: compound 1; then compound 2; then compound 3.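

In this assay, the step of a 230-fold higher number from compound 1 to compound 3 (2.35 log units; beyond the scatter) is the cleaner reading of this position: the six-membered aromatic ring of carbon stays on the carbonyl carbon, and only 4-methyl-1,4-diazepan-1-yl gives way to dimethylamino on an aromatic carbon. For the compounds shown here, the step of a 79-fold higher number from compound 2 to compound 3 (1.90 log units; beyond the scatter) is also large, so the low numbers of the earlier compounds do not survive with 4-(dimethylamino)phenyl in this place, and the group on that aromatic carbon matters far more than the gap between compound 1 and compound 2 suggested. No measurement shown explains this loss.

From the compounds shown here alone, whether the ring of the departing group or its terminal methyl-bearing amine is what counts remains open. A 4-methylpiperazin-1-yl, a morpholin-4-yl or an open aminoethyl chain on the same aromatic carbon would help to separate these readings.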